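Piperazine replacement on two pyridinyl cores: notes

A few compounds are considered here, and "the series" means these few. Any claim that something is new, unique, unknown or untested is made for them only; others in the source may bear on it.

Measured so far:
compound 1 `NC(=O)CN1CCN(c2nc(-c3ccccn3)nc3c2CN(Cc2ccccc2)CC3)CC1` — 57.9%
compound 2 `CN1CCN(CCCNc2nc(-c3ccccn3)nc3c2CN(Cc2ccccc2)CC3)CC1` — 53.4%
compound 3 `NC(=O)CN1CCN(c2nc(-c3cccnc3)nc3c2CN(Cc2ccccc2)CC3)CC1` — "not active" (no number reported)

In an assay on FRT cells with Cystic fibrosis transmembrane conductance regulator variant F508del (Homo sapiens) as the target, read by fluorescence, with a stated time of 25 min (on this read-out higher numbers stand for larger maximal responses and lower numbers for smaller maximal responses), compound 1 gives 57.9% and compound 2 gives 53.4%. The step between them is a number 4.5 percentage points lower from compound 1 to compound 2 (within the scatter), so the two values cannot be told apart here. The change that separates them is (3-(4-methylpiperazin-1-yl)propyl)amino in place of 4-(carbamoylmethyl)piperazin-1-yl on an aromatic carbon.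

Compound 3 carries a different core, and in this assay compound 3 is reported as "not active" (no number reported) without a number. The difference between the core of compound 1 and the core of compound 3 is pyridin-3-yl in place of pyridin-2-yl on an aromatic carbon.

Compound 4 `CN1CCN(CCCNc2nc(-c3cccnc3)nc3c2CN(Cc2ccccc2)CC3)CC1` is not yet measured. It stands to compound 3 as compound 2 stands to compound 1; the change is (3-(4-methylpiperazin-1-yl)propyl)amino in place of 4-(carbamoylmethyl)piperazin-1-yl on an aromatic carbon. Around the place the surroundings are not identical: in the pair of compound 1 and compound 2 the carbon is meta to a pyridin-2-yl group, in the pair of compound 3 and compound 4 it is meta to a pyridin-3-yl group, so this is the same kind of change, not the same change.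

For compound 4 in this assay the expectation rests on two observations. The same kind of change left the response of compound 1 and compound 2 within scatter of each other, and compound 3 itself gives "not active" (no number reported). Compound 4 is therefore estimated near 10% in this assay, with an expected range from 0% to 30%, and a sizeable chance that compound 4 is again reported without a number.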

Compound 4, largest response reached (Emax), in percent of the reference or control that the assay uses in the Cystic fibrosis transmembrane conductance regulator assay: "not active" (no number reported)
For compound 4 the study gives words and no number, so the estimate cannot be set against anything.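

No step can be read between compound 3 and compound 4 in the Cystic fibrosis transmembrane conductance regulator assay: both carry words and no number. In a physicochemical assay for solubility, read by HPLC, with a stated time of 24 h, at pH 7.4, tested at 250 uM (a higher number here means a more soluble compound, a lower number a less soluble compound), compound 3 gives 156000 nM and compound 4 gives 234000 nM, and the step reads a 1.5-fold higher number from compound 3 to compound 4 (0.18 log units; within the scatter) with nothing further to draw from it. The compounds shown leave open whether any group at this place gives a measurable response alongside pyridin-3-yl. No measurement at hand explains these two results.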